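A few compounds are considered here, and "the series" means these few. Any claim that something is new, unique, unknown or untested is made for them only; others in the source may bear on it.

Working notes on the series, read in a functional assay on THP-1 cells (Homo sapiens) for inhibition, read by sulforhodamine B assay, with a stated time of 48 h, tested at 50 uM; a higher number here means more inhibition of growth at the concentration tested, a lower number less inhibition of growth. Compound 1 (`COc1cc(/C=C/C(=O)/C=C/c2ccco2)ccc1OCc1cn(CCCOc2cc(=O)oc3ccccc23)nn1`) gives 57%, compound 2 (`COc1ccccc1/C=C/C(=O)/C=C/c1ccc(OCc2cn(CCCOc3cc(=O)oc4ccccc34)nn2)c(OC)c1`) gives 50%, and compound 3 (`COc1cc(/C=C/C(=O)/C=C/c2ccco2)ccc1OCc1cn(CCCCOc2cc(=O)oc3ccccc23)nn1`) gives 49%. Compound 2 lies within the scatter of both other compounds, so these numbers do not separate it from either.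

The next comparison is with compound 4 (`COc1ccc(/C=C/C(=O)/C=C/c2ccc(OCc3cn(CCCOc4cc(=O)oc5ccccc45)nn3)c(OC)c2)cc1OC`), which has 3,4-dimethoxyphenyl in place of 2-methoxyphenyl on a double-bonded chain carbon bound to a double-bonded chain carbon. The counted difference is 3,4-dimethoxyphenyl in place of 2-methoxyphenyl on a double-bonded chain carbon bound to a double-bonded chain carbon.

Within the data shown here, one measured step bears on this place, the exchange of furan-2-yl for 2-methoxyphenyl that links compound 1 and compound 2: a number 7 percentage points lower from compound 1 to compound 2 (within the scatter). That exchange replaced a whole group at the same place and did not move the number beyond the scatter. Among the measured compounds shown here, no measured compound yet carries 3,4-dimethoxyphenyl, so the data give no direction for this change. No step beyond the scatter is therefore expected in this assay.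

The estimated step is no change at the digits printed from compound 2 to compound 4 (within the scatter). For compound 4 the expected value is 50%, with an estimated range of 35% to 65%.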

Compound 4, percent growth inhibition at one concentration: 73%
Beside the measured number, compound 4's estimate is 23 percentage points below it; measured number outside the range, above it.
By their numbers in this assay, from the lowest: compounds 3, 2 and 1 (each within the scatter of the next); then compound 4.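

In this assay, the place on a double-bonded chain carbon bound to a double-bonded chain carbon now shows a step beyond the scatter: 3,4-dimethoxyphenyl in place of 2-methoxyphenyl gives a number 23 percentage points higher from compound 2 to compound 4 (beyond the scatter), and 3,4-dimethoxyphenyl in place of furan-2-yl gives a number 16 percentage points higher from compound 1 to compound 4 (beyond the scatter). The exchange of furan-2-yl for 2-methoxyphenyl at the same place gave only a number 7 percentage points lower from compound 1 to compound 2 (within the scatter), within the scatter, so the group at this place can move the number, and the choice of group matters more than the earlier pair suggested. No evidence is available on what lies behind the higher number with 3,4-dimethoxyphenyl.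

The compounds shown do not tell whether the step depends on having both methoxy groups, and an unsubstituted phenyl or a pyridine ring at this place would give a further comparison. Also open, as far as these compounds go, is whether 3,4-dimethoxyphenyl gives a step of similar size on the chain of compound 3, and whether these single-concentration readings would hold across a range of concentrations.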